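The source may report more compounds than this note shows. Statements on the series, on what has been measured and on what is new or still open speak of the compounds shown alone.

Measured so far in a physicochemical assay for solubility, at pH 7; a lower number here means a less soluble compound, a higher number a more soluble compound:
compound 1 `C[C@H]1Cc2[nH]nc(-c3ccccc3)c2CN1C(=O)Nc1cccc(Cl)c1` — 19000 nM
compound 2 `C[C@@H]1Cc2[nH]nc(-c3ccccc3)c2CN1C(=O)Nc1cccc(Cl)c1` — 20000 nM
compound 3 `CC[C@H]1Cc2[nH]nc(-c3ccccc3)c2CN1C(=O)Nc1cccc(Cl)c1` — 9000 nM

Compound 1 stands second highest of the three in this assay. Its nearest neighbour is compound 2, a 1.1-fold higher number from compound 1 to compound 2 (0.02 log units; within the scatter); the two compounds are mirror images at a single saturated ring carbon (the fact that compounds 1 and 2 differ only in the configuration as drawn). Compound 3 sits furthest away, a 2.1-fold lower number from compound 1 to compound 3 (0.32 log units; beyond the scatter), the result of a methyl in place of hydrogen on a saturated chain carbon bound to a saturated ring carbon.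

Compound 4 `C[C@H]1Cc2[nH]nc(-c3cccs3)c2CN1C(=O)Nc1cccc(Cl)c1` is not yet measured. It differs from compound 1 by thiophen-2-yl in place of phenyl on an aromatic carbon. Neither measured step bears on this change: the step from compound 1 to compound 2 concerns configuration only, and the step from compound 1 to compound 3 concerns a saturated chain carbon, whereas here one aromatic ring replaces another on the shared core. With nothing in the data that speaks to an aryl exchange, the expectation is a step within the scatter, a 1.1-fold higher number from compound 1 to compound 4 (0.02 log units; within the scatter). Compound 4 is therefore estimated at 20000 nM, within a range of 8000 nM to 50000 nM.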

Compound 4, solubility: 20000 nM
Beside the measured number, compound 4's estimate shows no gap at the digits printed; measured number inside the range.
By their numbers in this assay, from the lowest: compound 3; then compounds 1, 2 and 4 (each within the scatter of the next).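

This is the first change shown at this aromatic carbon, on the five-membered aromatic ring with 2 nitrogen, and in this assay the exchange of phenyl for thiophen-2-yl leaves the read-out within the scatter (a 1.1-fold higher number from compound 1 to compound 4 (0.02 log units; within the scatter)). One aromatic ring thus gave way to a smaller one carrying a sulfur and a hydrogen-bond acceptor with no step beyond the scatter, whereas the change on the saturated chain carbon did pass it (a 2.1-fold lower number from compound 1 to compound 3 (0.32 log units; beyond the scatter)). Nothing in the available evidence bears on why this exchange behaves as it does.

The compounds shown leave open whether a pyridine ring, or a phenyl carrying a carboxylic acid or an amine, would shift the number at this place. They also leave open whether thiophen-2-yl gives the same result on the ethyl-bearing core of compound 3.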